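Isopropyl in place of butyl on a sulfur

A few compounds are considered here, and "the series" means these few. Any claim that something is new, unique, unknown or untested is made for them only; others in the source may bear on it.

- compound 1 `CCC[S+]([O-])CCCCN=C=S` gives 7660 nM
- compound 2 `CCCC[S+]([O-])CCCCN=C=S` gives 6470 nM

Both numbers come from a functional assay on SH-SY5Y cells (Homo sapiens) for cytotoxicity, read by MTT assay, with a stated time of 72 h (on this read-out higher numbers stand for weaker inhibition and lower numbers for stronger inhibition), and lie within the usual scatter of each other, so these data cannot rank compound 2 against compound 1.

The next compound, compound 3 `CC(C)[S+]([O-])CCCCN=C=S`, has isopropyl in place of butyl on a sulfur and has not yet been measured.

Going by the values given here, only one measured step bears on this change. That step is a 1.2-fold lower number from compound 1 to compound 2 (0.07 log units; within the scatter) and it is methyl in place of hydrogen on a saturated chain carbon, three bonds along the chain from a sulfur. It stayed within the scatter, so the group on the sulfur made no clear difference between these two compounds. Neither measured compound carries isopropyl on the sulfur, so the range has to stay wide.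

No step beyond the scatter is expected in this assay here, and the estimated step is a 1.1-fold higher number from compound 2 to compound 3 (0.05 log units; within the scatter) on these numbers. For compound 3 the estimated value is 7200 nM with an expected range from 3800 nM to 13500 nM in this read-out.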

Compound 3, half-maximal inhibitory concentration: 9420 nM
Estimate against measurement, compound 3: 1.3-fold (0.12 log units) below; measured number inside the range.
By their numbers in this assay, from the lowest: compounds 2, 1 and 3 (each within the scatter of the next).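

In this assay the change at this position now includes a branched group as well as straight chains. Isopropyl in place of butyl on the sulfur gives (a 1.5-fold higher number from compound 2 to compound 3 (0.16 log units; within the scatter)), and isopropyl in place of propyl gives (a 1.2-fold higher number from compound 1 to compound 3 (0.09 log units; within the scatter)), so both steps stay within the scatter, and these data do not separate a branched group from a straight chain on this sulfur. No measurement shown gives a reason for these numbers.

The three compounds cover only small saturated carbon groups on the sulfur, so they leave open whether a phenyl ring, an amine or a much longer chain in that place would give a number clearly different from theirs. They also say nothing about the rest of the core, which is the same in all three, so the part of the structure that matters most for this cell read-out remains an open question.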